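The compounds below may be only part of what the source reports. "The series", "measured", "known", "first", "only" and "open" are said of these compounds alone.

Measured compounds and their values:

Compound 1, `COC(OC)C1=C(C(=O)OC/C=C/c2ccccc2)C(c2cccc(Cl)c2)C(C(=O)O)=C(C)N1`: in an assay on thoracic aorta for inhibition of Voltage-gated L-type calcium channel (Rattus norvegicus) (a lower number here means a stronger inhibitor, a higher number a weaker inhibitor), compound 1 gives 8100 nM
Compound 2, `CC1=C(C(=O)O)C(c2cccc(Cl)c2)C(C(=O)OC/C=C/c2ccccc2)=C(C#N)N1`: compound 2 gives 2000 nM
Compound 3, `COC(OC)C1=C(C(=O)OC/C=C/c2ccc(Cl)cc2)C(c2cccc(Cl)c2)C(C(=O)O)=C(C)N1`: compound 3 gives 1400 nM

Among these three numbers, compound 3 and compound 2 stand within the usual scatter of one another, whereas the step of a 5.8-fold lower number from compound 1 to compound 3 (0.76 log units; beyond the scatter) and the step of a 4.1-fold lower number from compound 1 to compound 2 (0.61 log units; beyond the scatter) both lie beyond it, so compound 3 is clearly separated from compound 1 alone.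

Compound 4, `COC(OC)C1=C(C(=O)OC/C=C/c2ccc(C(F)(F)F)cc2)C(c2cccc(Cl)c2)C(C(=O)O)=C(C)N1`, differs from compound 3 in one place: trifluoromethyl in place of chloro on an aromatic carbon. Within the data shown here, only one measured step touches this aromatic carbon, namely a 5.8-fold lower number from compound 1 to compound 3 (0.76 log units; beyond the scatter), where a chloro group entered in place of hydrogen. Among the measured compounds shown here, no measured step exchanges chloro for trifluoromethyl, so there is nothing in the data to set a direction for this change. Compound 4 is therefore expected to give a number close to that of compound 3, with a step of no change at the digits printed from compound 3 to compound 4 (within the scatter) that is estimated to stay within the scatter. The estimate for compound 4 is 1400 nM, with a range from 500 nM to 4000 nM.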

Compound 4, half-maximal inhibitory concentration: 3200 nM
Beside the measured number, compound 4's estimate is 2.3-fold (0.36 log units) below it; low and high end bracket the measured number.
By their numbers in this assay, from the lowest: compounds 3, 2 and 4 (each within the scatter of the next, the first and the last beyond it); then compound 1.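

In this assay, the aromatic carbon para to a large group now shows that its substituents are not interchangeable: exchanging chloro for trifluoromethyl gives a 2.3-fold higher number from compound 3 to compound 4 (0.36 log units; beyond the scatter), so the two groups can be told apart at this position even though the step is modest. Trifluoromethyl still retains a gain over hydrogen, with a 2.5-fold lower number from compound 1 to compound 4 (0.40 log units; beyond the scatter), although chloro gives the lowest number of the three groups tried on this carbon. Nothing available explains the difference between chloro and trifluoromethyl here.

From the compounds shown here alone, whether a methoxy group or an amine on this same carbon would give a number nearer that of chloro or that of hydrogen remains open. Also open, going by these compounds, is whether trifluoromethyl here would give a comparable step on a compound carrying cyano in place of dimethoxymethyl.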